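N-Hydroxy to N-H on a Pyrrole Nitrogen

The source may report more compounds than this note shows. Statements on the series, on what has been measured and on what is new or still open speak of the compounds shown alone.

Measured compounds:
Compound 1 `CCCn1c(=O)c2[nH]ccc2n(CCC)c1=O` 440 nM
Compound 2 `Cn1c(=O)c2c(cc(/C=C/c3ccccc3)n2O)n(C)c1=O` 560 nM

In an assay for binding affinity to adenosine receptor A1 (Rattus norvegicus), in the presence of a further agent that is not named here (on this read-out lower numbers stand for stronger inhibition and higher numbers for weaker inhibition), compound 1 gives 440 nM and compound 2 gives 560 nM. Compound 2 stands at the higher of the two numbers, yet its gap to compound 1 lies within the usual scatter, so the two cannot be told apart on this read-out. Compound 3 `Cn1c(=O)c2[nH]c(/C=C/c3ccccc3)cc2n(C)c1=O` has not yet been measured in this assay. It differs from compound 2 in one place: hydrogen in place of hydroxy on an aromatic nitrogen, a hydrogen in place of hydroxy on an aromatic nitrogen. Within the data shown here, no measured pair shows this change on its own, so there is no step to lean on. Compound 3 is expected to land close to compound 2, with the step of a 1.4-fold lower number from compound 2 to compound 3 (0.15 log units; within the scatter) small and in either direction. The estimate for compound 3 in this assay is 400 nM, with a range from 100 nM to 1600 nM.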

Compound 3, inhibition constant: 165 nM
The estimate for compound 3 lay 2.4-fold (0.38 log units) above the measured number; the measured number falls inside the stated range.
By their numbers in this assay, from the lowest: compound 3; then compounds 1 and 2 (each within the scatter of the next).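

In this assay, hydrogen in place of hydroxy on the aromatic nitrogen gives a 3.4-fold lower number from compound 2 to compound 3 (0.53 log units; beyond the scatter) and so shows that this position does not tolerate the change without consequence, even though the group leaving holds only one heavy atom. Among these compounds, this pair is the first to isolate any change at this nitrogen, and here the hydroxy goes with the higher number and the hydrogen with the lower, on a core that keeps the group of 8 heavy atoms on the neighbouring ring atom. Nothing shown bears on why the number moves.

Whether the step reflects the loss of hydroxy alone or is specific to hydrogen remains open, since a methoxy or methyl group on this nitrogen does not appear among these compounds. Equally open, from the compounds shown here alone, is whether a longer chain such as ethyl would be accepted at this nitrogen.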